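The source may hold more compounds than are shown below. What is called first, only, known or untested is meant among the compounds shown, and "the series" means these compounds.

Working notes on the series. Three analogues share a core built from a chlorobenzyl-bearing bicycle. Compound 1 `Cc1ccc(-c2cn3nc(Cc4ccc(Cl)cc4)sc3n2)cc1` carries a 4-methylphenyl group and no bromine on the core. Compound 2 `Fc1ccc(-c2nc3sc(Cc4ccc(Cl)cc4)nn3c2Br)cc1` carries a 4-fluorophenyl group with bromine on the core. Compound 3 `COc1ccc(-c2nc3sc(Cc4ccc(Cl)cc4)nn3c2Br)cc1` carries a 4-methoxyphenyl group with the same bromine.

In an ADME assay on CCRF-CEM cells (Homo sapiens) for cytotoxicity, with a stated time of 72 h (a lower number here means a stronger inhibitor, a higher number a weaker inhibitor), compound 1 gives only a limit of > 250000 nM. In this assay compound 2 likewise gives only a limit of > 250000 nM. In this assay, among the compounds with values here, compound 3 gives 58000 nM, the one number the series yields so far. Compound 1 and compound 2 stand at a limit (the limit of > 250000 nM in this assay, at which 2 of the 3 values shown sit). Within the data shown here, the single measured step, an at least 4.3-fold lower number from compound 2 to compound 3 (0.63 log units; beyond the scatter), is the only comparison available.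

The next compound, compound 4 `Cc1ccc(-c2nc3sc(Cc4ccc(Cl)cc4)nn3c2Br)cc1`, differs from compound 3 by methyl in place of methoxy on an aromatic carbon. Among the measured compounds shown here, no measured step covers methyl against methoxy. The nearest anchor is compound 1, which carries the same 4-methylphenyl group without bromine on the core. In this assay compound 1 gives only a limit of > 250000 nM. In this assay compound 4 is therefore expected to be weak, with an estimated step of a 3.1-fold higher number from compound 3 to compound 4 (0.49 log units; beyond the scatter), giving an estimate of 180000 nM within a range of 60000 nM to 500000 nM.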

Compound 4, half-maximal inhibitory concentration: > 250000 nM
Compound 4: only a limit was reported; the forecaster's own chance of this, stated with the estimate: 60%; at least 1.3-fold (0.14 log units) between middle value and limit.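

In this assay, methyl in place of methoxy on the aromatic carbon para to a large group gives an at least 4.3-fold higher number from compound 3 to compound 4 (0.63 log units; beyond the scatter), so the earlier fluoro result is no longer the only one that separates from methoxy at this position. Among the compounds with bromine on the core, only the 4-methoxyphenyl group has so far given a number rather than a limit: the limit of > 250000 nM in this assay, at which 3 of the 4 values shown sit. The steps from compound 2 to compound 4 and from compound 1 to compound 4 cannot be read, since both ends are limits, so neither methyl against fluoro nor the effect of bromine can be sized.

Open, going by these compounds, is whether an amine or a longer alkoxy chain on this aromatic carbon would lower the number further than methoxy. Also open, on these data alone, is whether the 4-methoxyphenyl group gives a number without bromine on the core.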